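Phenyl in Place of Fluoropyridinyloxy in a Muscarinic Modulator Series

The source may hold more compounds than are shown below. What is called first, only, known or untested is meant among the compounds shown, and "the series" means these compounds.

Measured so far:
compound 1, `O=C1C(=O)N(Cc2ccc(-c3cncnc3)cc2)c2ccc(OC(F)(F)F)cc21`, gives 53% in a functional assay on CHO cells for positive allosteric modulation of muscarinic acetylcholine receptor M5 (Homo sapiens), read by FLIPR and calcium flux, with a stated time of 1 h; on this read-out higher numbers stand for larger maximal responses and lower numbers for smaller maximal responses
compound 2, `O=C1C(=O)N(Cc2ccc(Oc3cccc(F)n3)cc2)c2ccc(OC(F)(F)F)cc21`, gives 62% in this assay

Compound 2 holds the highest of the two numbers, and compound 1 is its nearest neighbour, the two separated by a number 9 percentage points higher from compound 1 to compound 2 (within the scatter). Compound 3, `O=C1C(=O)N(Cc2ccc(-c3ccccc3)cc2)c2ccc(OC(F)(F)F)cc21`, has not been measured. It differs from compound 2 in one place: phenyl in place of (6-fluoropyridin-2-yl)oxy on an aromatic carbon. Within the data shown here, only one measured step bears on this change, a number 9 percentage points higher from compound 1 to compound 2 (within the scatter), which was itself small, and it introduced the very (6-fluoropyridin-2-yl)oxy group that compound 3 now lacks. Among the measured compounds shown here, compound 3 therefore sits closer in build to compound 1 than to compound 2, and the single available comparison gives no reason to expect a move beyond the scatter. The step from compound 2 to compound 3 is estimated at a number 9 percentage points lower from compound 2 to compound 3 (within the scatter), pointing slightly downward. Compound 3 is accordingly expected to give 53% in this assay, within a range from 36% to 70%.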

Compound 3, largest response reached (Emax), in percent of the reference or control that the assay uses: < 60%
Compound 3 was reported as a limit; the forecaster's own chance of this, stated with the estimate: 5%; the middle value is on the limit's open side.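

In this assay compound 3 is reported only as a limit, < 60%. Exchanging (6-fluoropyridin-2-yl)oxy for phenyl on this aromatic carbon, para to a large group, gives a number at least 2 percentage points lower from compound 2 to compound 3 (that floor lies within the scatter), so the result shows a direction for this change but no loss that can be told from the scatter. The step from compound 1 to compound 3 cannot be read from a limit, so phenyl and pyrimidin-5-yl cannot be ranked at this position.

The compounds shown leave open how far the maximal response of compound 3 actually lies under its limit. They also leave open whether a simple phenoxy group, an amine or a carboxylic acid at this position would move the response beyond the scatter.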